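Swapping chlorine for fluorine on a sulfone-bearing enone

A few compounds are considered here, and "the series" means these few. Any claim that something is new, unique, unknown or untested is made for them only; others in the source may bear on it.

Compound 2 `O=C(/C(=C\c1ccc(Cl)cc1Cl)S(=O)(=O)c1ccc(Br)cc1)c1ccc(Br)cc1` is tested in a functional assay on DU-145 cells (Homo sapiens) for inhibition, read by trypan blue exclusion, with a stated time of 96 h (on this read-out higher numbers stand for weaker inhibition of growth and lower numbers for stronger inhibition of growth), where compound 2 gives 10000 nM. Two related compounds have been measured alongside it. Compound 1 `O=C(/C(=C\c1ccccc1OCc1ccccc1)SCc1ccc(Cl)c(Cl)c1)c1ccc(Cl)cc1` gives 10000 nM, so compound 2 stands level with compound 1 at the digits shown, and the two together hold the lowest numbers of the three. Within the data shown here, compound 3 `COc1ccc(S(=O)(=O)/C(=C/c2ccc(Cl)cc2Cl)C(=O)c2ccc(Br)cc2)cc1` gives 20000 nM; the only single-place step among the measured compounds runs from compound 2 to compound 3 and amounts to a 2.0-fold higher number from compound 2 to compound 3 (0.30 log units; within the scatter), a shift that stays inside the ordinary scatter of repeated tests.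

Compound 4 `O=C(/C(=C\c1ccc(F)cc1F)S(=O)(=O)c1ccc(Br)cc1)c1ccc(Br)cc1` has not yet been measured. It differs from compound 2 in one place: 2,4-difluorophenyl in place of 2,4-dichlorophenyl on a double-bonded chain carbon bound to a double-bonded chain carbon. Among the measured compounds shown here, no measured step touches that part of the molecule, and the one step that exists, from compound 2 to compound 3, concerns another position and did not move beyond the scatter. The shared core therefore looks tolerant of small changes so far, but a direct precedent for this one is absent.

On that basis, compound 4 is expected to give about 10000 nM, within a range from 5000 nM to 20000 nM, which would mean an estimated step of no change at the digits printed from compound 2 to compound 4 (within the scatter).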

Compound 4, concentration for 50% growth inhibition: 7500 nM
Beside the measured number, compound 4's estimate is 1.3-fold (0.12 log units) above it, within the range that was stated.
By their numbers in this assay, from the lowest: compounds 4, 1, 2 and 3 (each within the scatter of the next, the first and the last beyond it).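

Among these compounds, this pair gives the first direct look at this position: in this assay, 2,4-difluorophenyl in place of 2,4-dichlorophenyl on a double-bonded chain carbon bound to a double-bonded chain carbon gives a 1.3-fold lower number from compound 2 to compound 4 (0.12 log units; within the scatter). That step lies within the scatter, so for this pair, exchanging chlorine for fluorine on this ring leaves no difference in growth inhibition that can be told apart from the ordinary variation between repeated tests. Nothing available here bears on why the two halogen-bearing rings read alike, so the result stands as an observation without an explanation.

The compounds shown leave open whether this position accepts groups of a quite different kind, such as an amine, a carboxylic acid or a longer chain in place of the 2,4-dichlorophenyl group. Going by these compounds, with a single step at this position, it also remains open whether any change here can move the number beyond the scatter, in either direction.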